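From 4-chlorophenyl to 2-fluorophenyl: working notes on the series

The source may hold more compounds than are shown below. What is called first, only, known or untested is meant among the compounds shown, and "the series" means these compounds.

In a functional assay on MCF7 cells (Homo sapiens) for inhibition, read by MTT assay, with a stated time of 48 h (a higher number here means a weaker inhibitor of growth, a lower number a stronger inhibitor of growth), compound 1 `CN1CC[C@H](c2c(O)cc(O)c3c(=O)cc(/C=C/c4ccccc4)oc23)[C@H](O)C1` gives 31000 nM and compound 2 `CN1CC[C@H](c2c(O)cc(O)c3c(=O)cc(/C=C/c4ccc(Cl)cc4)oc23)[C@H](O)C1` gives 49000 nM. These two numbers lie within the scatter of each other, so compound 2 stands level with compound 1. Compound 3 `CN1CC[C@H](c2c(O)cc(O)c3c(=O)cc(/C=C/c4ccccc4F)oc23)[C@H](O)C1` has no number yet. Its change from compound 2 is 2-fluorophenyl in place of 4-chlorophenyl on a double-bonded chain carbon bound to a double-bonded chain carbon, in words 2-fluorophenyl in place of 4-chlorophenyl on a double-bonded chain carbon bound to a double-bonded chain carbon. Within the data shown here, only one measured step bears on this: a 1.6-fold higher number from compound 1 to compound 2 (0.20 log units; within the scatter), for chloro in place of hydrogen on an aromatic carbon. Among the measured compounds shown here, no measured compound carries 2-fluorophenyl, so that step is indirect evidence. No step beyond the scatter is expected in this assay, and neither direction is favoured. The expected step is a 1.3-fold lower number from compound 2 to compound 3 (0.11 log units; within the scatter). Compound 3 is estimated at 38000 nM, with an expected range of 17000 nM to 85000 nM.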

Compound 3, concentration for 50% growth inhibition: 8000 nM
Estimate against measurement, compound 3: 4.8-fold (0.68 log units) above; measured number below the stated range.
By their numbers in this assay, from the lowest: compound 3; then compounds 1 and 2 (each within the scatter of the next).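

In this assay the aryl group on the double-bonded chain carbon turns out to be a place where the number can move: there is a 6.1-fold lower number from compound 2 to compound 3 (0.79 log units; beyond the scatter) for 2-fluorophenyl in place of 4-chlorophenyl, whereas the earlier chloro step stayed within the scatter. The change also holds against the compound without a halogen, with a 3.9-fold lower number from compound 1 to compound 3 (0.59 log units; beyond the scatter). Nothing at hand accounts for this difference.

The compounds shown do not separate the halogen from its place on the ring, which 4-fluorophenyl and 2-chlorophenyl would do. As far as these compounds go, how far the trend extends to other groups on the phenyl ring, such as methoxy or an amine, also remains open.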